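The source may hold more compounds than are shown below. What is called first, only, known or untested is meant among the compounds shown, and "the series" means these compounds.

Compounds measured: compound 1 `CNC(=O)c1cnc(C(=O)CCCCCCc2ccccc2)o1` gives 7 nM; compound 2 `O=C(CCCCCCc1ccccc1)c1ncc(C(=O)N2CCOCC2)o1` gives 24 nM.

In an assay (Rattus norvegicus) for inhibition of Fatty-acid amide hydrolase 1 (Homo sapiens) (a lower number here means a stronger inhibitor, a higher number a weaker inhibitor), compound 2 has the highest of the two numbers, with compound 1 the nearest at a lower value. Compound 3 `O=C(CCCCCCc1ccccc1)c1ncc(Cl)o1` differs from compound 2 by chloro in place of (morpholin-4-yl)carbonyl on an aromatic carbon. For the measured compounds named here, the single measured step, a 3.4-fold higher number from compound 1 to compound 2 (0.54 log units; beyond the scatter), only changed the amine on the carbonyl; no step shows removal of the whole carbonyl group, so the expectation rests on thin ground. Compound 3 is therefore expected to give a modestly higher number, a 3.3-fold higher number from compound 2 to compound 3 (0.52 log units; beyond the scatter), with the estimate 80 nM and a range from 20 nM to 320 nM.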

Compound 3, inhibition constant: 5 nM
The estimate for compound 3 lay 16-fold (1.20 log units) above the measured number; the measured number lies below the stated range.
By their numbers in this assay, from the lowest: compounds 3 and 1 (each within the scatter of the next); then compound 2.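

In this assay the whole carbonyl unit proves dispensable on this aromatic carbon next to the ring oxygen: chloro, a single heavy atom with no hydrogen-bond acceptors, gives a 4.8-fold lower number from compound 2 to compound 3 (0.68 log units; beyond the scatter) in place of the morpholine amide. Set against the methylcarbamoyl group, the same chloro gives a 1.4-fold lower number from compound 1 to compound 3 (0.15 log units; within the scatter) so an amide at this place is not required for a number of this size. From the compounds shown here alone, whether bromo, a nitrile or a carboxylic acid would behave like chloro here stays open, as does a bare hydrogen at this carbon. Nothing given here explains why chloro matches the methylcarbamoyl group.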